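Removing a trifluoromethyl from an amide at the assay limit

The compounds below may be only part of what the source reports. "The series", "measured", "known", "first", "only" and "open" are said of these compounds alone.

compound 1 `COc1cc(-c2nn(-c3cccc(NC(=O)c4cccc(C(F)(F)F)c4)c3)cc2-c2ccncc2)ccc1Cl`: > 50000 nM
compound 2 `O=C(Nc1cccc(-n2cc(-c3ccncc3)c(-c3ccc(Cl)c(O)c3)n2)c1)Nc1cc(C(F)(F)F)cc(C(F)(F)F)c1`: 4360 nM

In a functional assay on MOLT-4 cells (Homo sapiens) for inhibition, read by sulforhodamine B assay, with a stated time of 48 h (on this read-out higher numbers stand for weaker inhibition of growth and lower numbers for stronger inhibition of growth), compound 1 reaches only the limit of the assay and gives > 50000 nM, which is a limit and not a number. This stands as the limit of > 50000 nM in this assay, at which 1 of the 2 values shown sits. Compound 2, a urea with a different aryl partner and a hydroxyl in place of the methoxy, gives 4360 nM in this assay; no single-point step connects it to compound 1, so the two values are simply shown side by side.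

Compound 3 `COc1cc(-c2nn(-c3cccc(NC(=O)c4ccccc4)c3)cc2-c2ccncc2)ccc1Cl` differs from compound 1 in one place: hydrogen in place of trifluoromethyl on an aromatic carbon, meta to a large group. No measured step of this kind exists among these compounds, and compound 1 itself sits at the limit, so nothing here measures what the change does to growth inhibition. The removal of the trifluoromethyl is expected to leave compound 3 near the limit, with the expected step that the limit leaves unreadable from compound 1 to compound 3 being none beyond the scatter. Compound 3 is thus estimated at 60000 nM in this assay, with a range from 15000 nM to 200000 nM, and most likely it will again be reported only as a limit.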

Compound 3, concentration for total growth inhibition: > 100000 nM
Compound 3 gave a limit, no number (the forecaster's own chance of this, stated with the estimate: 75%); middle value at least 1.6-fold (0.22 log units) away from the limit.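

In this assay compound 3 gives > 100000 nM, which is a limit and not a number. Among these compounds, compound 1 also stands at a limit, so no step between compound 1 and compound 3 can be read. The compounds shown leave open whether hydrogen in place of trifluoromethyl changes growth inhibition at all.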